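A few compounds are considered here, and "the series" means these few. Any claim that something is new, unique, unknown or untested is made for them only; others in the source may bear on it.

The shared core of these compounds carries a 2-phenylethenyl group, and compound 1 `CC(C)(C)OC(=O)NCCNc1cc(/C=C/c2ccccc2)nc2ccccc12`, compound 2 `CC(C)(C)OC(=O)NCCCCNc1cc(/C=C/c2ccccc2)nc2ccccc12` and compound 3 `CC(=O)N(C(C)=O)c1cc(/C=C/c2ccccc2)nc2ccccc12` differ in the group attached to that core. In an ADME assay on J774 cells (Mus musculus) for cytotoxicity, read by MTT assay, with a stated time of 48 h (on this read-out lower numbers stand for stronger inhibition and higher numbers for weaker inhibition), compound 1 gives 6600 nM. In this assay compound 2 gives 3700 nM, so the change a 1.8-fold lower number from compound 1 to compound 2 (0.25 log units; within the scatter) stays within the scatter of the method. For compound 3 this assay reports only a limit, > 25000 nM. That places compound 3 at the limit of > 25000 nM in this assay, at which 1 of the 3 values shown sits, with no exact number behind it, which is the only thing known about where it stands.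

Compound 4 `C(=C/c1cc(-c2c[nH]c3ccccc23)c2ccccc2n1)\c1ccccc1` has not yet been measured. It differs from compound 3 in one place: 1H-indol-3-yl in place of diacetylamino on an aromatic carbon. Within the data shown here, no measured step bears on this exchange. Among the measured compounds shown here, the one step with a number concerns a chain on a different substituent, and compound 3 itself offers only a limit, so neither the direction nor the size of the step from the diacetylamino compound to the indolyl compound can be read from what has been measured. The step of an at least 1.6-fold lower number from compound 3 to compound 4 (0.22 log units; that floor lies within the scatter) is therefore expected only loosely, with a wide range. In this assay compound 4 is estimated to give 15000 nM, between 3000 nM and 50000 nM.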

Compound 4, half-maximal inhibitory concentration: 4100 nM
Compound 4: the middle estimate sits 3.7-fold (0.56 log units) above what was measured, within the range that was stated.
By their numbers in this assay, from the lowest: compounds 2, 4 and 1 (each within the scatter of the next). At a limit, above all of these: compound 3.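

Among these compounds, until now, the only step with a number was a change in chain length on the group attached to the shared core, and it stayed within the scatter. Compound 4 gives the first readable step from exchanging the group itself on this aromatic carbon, opposite the ring nitrogen. In this assay, putting 1H-indol-3-yl in place of diacetylamino gives an at least 6.0-fold lower number from compound 3 to compound 4 (0.78 log units; beyond the scatter), so the choice of group at this position can move the cytotoxicity number beyond the scatter. The value for compound 3 is a limit and not a number, so this step is only a floor: the limit of > 25000 nM in this assay, at which 1 of the 4 values shown sits.

The exchange changes several things at once, replacing a group with no ring and two carbonyl groups by one with two aromatic rings and a hydrogen-bond donor, so the compounds shown cannot say which of these differences matters. From the compounds shown here alone, it also remains open whether a plain phenyl ring, a simple amine, or an indole carrying a methyl group in place of its ring hydrogen would give a number close to that of compound 4 at this position.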